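The compounds below may be only part of what the source reports. "The series", "measured", "known", "first", "only" and "open" are said of these compounds alone.

Among the measured compounds shown here, compound 1 `COc1cc(N2CCN(C(=O)Cn3cnc4cccc(C(F)(F)F)c43)CC2)ccc1-c1cnc(C)o1` is one of two compounds measured in an ADME assay on microsomes from liver (Rattus norvegicus) for metabolic stability, read by LC-MS; a higher number here means faster removal of the compound, a lower number slower removal. In this assay compound 1 gives 7 mL.min-1.g-1, the lowest of the two numbers. For the measured compounds named here, the other measured compound, compound 2 `COc1cc(N2CCN(C(=O)Cn3cnc4cc(C(F)(F)F)ccc43)C[C@@H]2C)ccc1-c1cnc(C)o1`, gives 67 mL.min-1.g-1 in this assay; the two structures differ in more than one place, so their values stand side by side without a single step connecting them, and together they show only that the shared core can be cleared at quite different rates.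

Compound 3 `COc1cc(N2CCN(C(=O)Cn3cnc4ccccc43)CC2)ccc1-c1cnc(C)o1` has not yet been measured. It is reached from compound 1 by one change, (hydrogen in place of trifluoromethyl on an aromatic carbon). Going by the values given here, no step between two measured compounds matches this change, so there is nothing in the measured pair that fixes its size or direction. The expectation drawn from compound 1, with its value of 7 mL.min-1.g-1 as the starting point, is a step of a 2.1-fold higher number from compound 1 to compound 3 (0.33 log units; beyond the scatter) upward, modest and possibly within the scatter. On that basis compound 3 is estimated to give 15 mL.min-1.g-1 in this assay, with a range from 6 mL.min-1.g-1 to 45 mL.min-1.g-1.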

Compound 3, intrinsic clearance in microsomes: 22 mL.min-1.g-1
Compound 3: middle estimate off by 1.5-fold (0.17 log units), on the low side; the range from low to high includes it.
By their numbers in this assay, from the lowest: compound 1; then compound 3; then compound 2.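

Among the compounds shown here, replacing trifluoromethyl with hydrogen on this aromatic carbon gives, in this assay, a 3.1-fold higher number from compound 1 to compound 3 (0.50 log units; beyond the scatter), the first step that can be read at a single position. For the compounds shown here, the step lies beyond the usual scatter, so in this pair the compound carrying trifluoromethyl has the lower number, while the compound with hydrogen at that carbon still stays well short of the high number printed for compound 2, which differs from both in more than one place and gives no step here. No measurement at hand accounts for the size or direction of this step.

Going by these compounds, with only hydrogen and trifluoromethyl compared at this carbon, it remains open whether a smaller group such as fluorine or chlorine, a methyl group, a nitrile or a methoxy group would give a number nearer to that of compound 1 or of compound 3. Going by these compounds alone, it also remains open whether the same exchange would give a step of similar size and direction on another background, since this single pair is the only reading of the change.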